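The source may hold more compounds than are shown below. What is called first, only, known or untested is meant among the compounds shown, and "the series" means these compounds.

Notes on the series in an ADME assay on cells (Hepatocyte, Mus musculus) for metabolic stability; on this read-out higher numbers stand for a longer-lived compound and lower numbers for a shorter-lived compound. Going by the values given here, compound 1 (`O=C(OC1CCC(CN2CCN(c3cc(=O)c4cc(C(F)(F)F)cc([N+](=O)[O-])c4s3)CC2)CC1)c1ccncc1`) gives 0.0817 h, the only actual number in the set. Compound 2 (`CC(=O)OC1CCC(CN2CCN(c3cc(=O)c4cc(C(F)(F)F)cc([N+](=O)[O-])c4s3)CC2)CC1`) reports only a limit, < 0.15 h. Compound 3 (`O=C(OC1CCC(CN2CCN(c3cc(=O)c4cc(C(F)(F)F)cc([N+](=O)[O-])c4s3)CC2)CC1)c1ccco1`) likewise reports only a limit, < 0.075 h, so its true position is not known.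

The next change leads to compound 4 (`O=C(OC1CCC(CN2CCN(c3cc(=O)c4cc(C(F)(F)F)cc([N+](=O)[O-])c4s3)CC2)CC1)c1ccc(F)cc1`), with 4-fluorophenyl in place of furan-2-yl on a carbonyl carbon.

All three measured steps concern this same group. The one partly readable is an at least 1.0-fold lower number from compound 1 to compound 3 (0.03 log units; that floor lies within the scatter). The others are a step that the limit leaves unreadable from compound 1 to compound 2 and a step that the two limits leave unreadable from compound 2 to compound 3. None of them therefore shows a change beyond the scatter, and none gives a direction for the new group.

No step beyond the scatter is expected in this assay, and the expectation rests mainly on compound 1 at 0.0817 h. As an estimate, this amounts to a step that the limit leaves unreadable from compound 3 to compound 4. For compound 4 the expected half-life is 0.07 h, with an estimated range of 0.03 h to 0.15 h.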

Compound 4, half-life: 0.0817 h
Estimate against measurement, compound 4: 1.2-fold (0.07 log units) below; measured number inside the range.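

Going by these compounds alone, on the carbonyl carbon, the exchange of pyridin-4-yl for 4-fluorophenyl gives the first comparison between two actual numbers in this assay, and it reads no change at the digits printed from compound 1 to compound 4 (within the scatter). Against furan-2-yl, the step reads an at least 1.0-fold higher number from compound 3 to compound 4 (0.03 log units; that floor lies within the scatter). Compound 3 is a limit, so that step gives only a floor and its true size stays unknown: the limit of < 0.075 h in this assay, at which 1 of the 4 values shown sits.

Going by these compounds, compound 2 is also a limit, and its step to compound 4 cannot be read: the limit of < 0.15 h in this assay, at which 1 of the 4 values shown sits. Still open is whether any group on this carbonyl carbon moves the half-life beyond the scatter, for example a cyclohexyl group or a longer chain, and whether a change elsewhere on the shared core does so.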